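Methyl on the hydrazine nitrogen of the series core

A few compounds are considered here, and "the series" means these few. Any claim that something is new, unique, unknown or untested is made for them only; others in the source may bear on it.

Measured so far:
compound 1 `CCOC(=O)c1cnc(CC)nc1NN1C(=O)C=C(C)C1=O` — 10000 nM
compound 2 `CCOC(=O)c1cnc(-c2cc(Cl)cc(Cl)c2)nc1NN1C(=O)C=C(C)C1=O` — 300 nM

In a functional assay on Jurkat cells for inhibition of nuclear factor NF-kappa-B complex (Homo sapiens) (a higher number here means a weaker inhibitor, a lower number a stronger inhibitor), compound 1 gives 10000 nM, the higher of the two numbers at hand; compound 2 gives 300 nM. Going by the values given here, the one measured step, a 33-fold lower number from compound 1 to compound 2 (1.52 log units; beyond the scatter), concerns the substituent on an aromatic carbon.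

Compound 3 `CCOC(=O)c1cnc(CC)nc1N(C)N1C(=O)C=C(C)C1=O` differs from compound 1 by methyl in place of hydrogen on a nitrogen on an aromatic ring. Among the compounds with values here, no measured step touches this nitrogen; the step from compound 1 to compound 2 sits elsewhere on the core and says nothing about what a methyl on the nitrogen does. With nothing to go on beyond the two numbers shown, the working expectation is a step of no change at the digits printed from compound 1 to compound 3 (within the scatter), that is, a number within the scatter of compound 1. For compound 3 the estimate is 10000 nM, with a range of 3000 nM to 30000 nM, and the value may well be reported only as a limit.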

Compound 3, half-maximal inhibitory concentration: 10000 nM
Beside the measured number, compound 3's estimate shows no gap at the digits printed, within the range that was stated.
By their numbers in this assay, from the lowest: compound 2; then compounds 1 and 3 (each within the scatter of the next).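

In this assay, methyl in place of hydrogen on a nitrogen on an aromatic ring gives no change at the digits printed from compound 1 to compound 3 (within the scatter). Going by these compounds alone, this is the first reading at this nitrogen; the earlier step lay on an aromatic carbon. With ethyl on that carbon, the hydrogen on this nitrogen can be exchanged for methyl without a difference beyond the scatter, but no information on hand explains this result.

From the compounds shown here alone, the reading comes only from the ethyl series, whose numbers are higher than that of compound 2, so it remains open whether methyl on this nitrogen would also leave the number unchanged with 3,5-dichlorophenyl on the aromatic carbon. Also open, going by these compounds, is how this nitrogen responds to a longer chain such as propyl or to an acetyl group.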